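Extending the acetoxy chain of compound 2

The source may report more compounds than this note shows. Statements on the series, on what has been measured and on what is new or still open speak of the compounds shown alone.

Measured compounds:
compound 1, `CC(=O)OCc1ccc2oc(=O)c(C(=O)Oc3cccc(Cl)c3)cc2c1`: 6.17%
compound 2, `CC(=O)OCc1ccc2oc(=O)c(C(=O)Oc3cccc(Br)c3)cc2c1`: 11.8%
compound 3, `CC(=O)OCc1ccc2oc(=O)c(C(=O)Sc3ccccc3)cc2c1`: 73.8%

In a functional assay on HT-1080 cells (Homo sapiens), read by transwell migration, with a stated time of 24 h, tested at 10 uM (a higher number here means a weaker effect of the compound at the concentration tested, a lower number a stronger effect), compound 2 gives 11.8%, the second highest of the three numbers. Its nearest neighbour is compound 1, with a number 5.6 percentage points higher from compound 1 to compound 2 (within the scatter), a gap within the scatter; furthest away lies compound 3, with a number 62 percentage points higher from compound 2 to compound 3 (beyond the scatter), a large step beyond the scatter.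

Compound 4, `CCCCC(=O)OCc1ccc2oc(=O)c(C(=O)Oc3cccc(Br)c3)cc2c1`, differs from compound 2 in one place: propyl in place of hydrogen on a saturated chain carbon bound to a carbonyl carbon. Among the compounds with values here, none of the measured steps touches this part of the shared core. The steps of a number 67.6 percentage points higher from compound 1 to compound 3 (beyond the scatter) and a number 62 percentage points higher from compound 2 to compound 3 (beyond the scatter) concern the group on the carbonyl carbon of the other side chain, and a number 5.6 percentage points higher from compound 1 to compound 2 (within the scatter) changes only the ring substituent. The data therefore give no direct guide to what a propyl in place of hydrogen here will do. For compound 4 the expectation is a number 6.2 percentage points higher from compound 2 to compound 4 (within the scatter), a step that may well stay within the scatter. The estimated value for compound 4 in this assay is 18%, with a range from 4% to 45%.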

Compound 4, a percentage reported as activity, at one concentration (the size of the read-out at that concentration, not a potency): 32.3%
For compound 4 the middle estimate is 14.3 percentage points below the measured one, and the stated range covers the measured number.
By their numbers in this assay, from the lowest: compounds 1 and 2 (each within the scatter of the next); then compound 4; then compound 3.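

Within the data shown here, compound 4 gives the first reading at this position: in this assay, changing acetoxy to (butylcarbonyl)oxy gives a number 20.5 percentage points higher from compound 2 to compound 4 (beyond the scatter) as a modest step. The side of the shared core carrying this ester is therefore not silent, since the longer chain on a saturated chain carbon bound to a carbonyl carbon leaves a weaker effect at the concentration tested. No measurement shown here accounts for this step.

The compounds shown leave open whether the number keeps rising as the chain grows, or how an ethyl group, a longer chain such as hexyl, or an amine or carboxylic acid at the chain end would read. They also leave open whether the same change would give a similar step with 3-chlorophenoxy or phenylsulfanyl on the other side chain.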